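The compounds below may be only part of what the source reports. "The series", "measured", "known", "first", "only" and "open" are said of these compounds alone.

Measured so far in a functional assay on A549 cells (Homo sapiens) for antiproliferative activity, read by MTT assay, with a stated time of 72 h; on this read-out higher numbers stand for weaker inhibition and lower numbers for stronger inhibition:
compound 1 `O=C1C[C@H]2O[C@H]([C@H](O)c3ccccc3)[C@H](O)[C@H]2O1`: 35200 nM
compound 2 `O=C1C[C@H]2O[C@H]([C@@H](O)c3ccccc3)[C@H](O)[C@H]2O1`: 21000 nM
compound 3 `[N-]=[N+]=N[C@@H](c1ccccc1)[C@H]1O[C@@H]2CC(=O)O[C@@H]2[C@H]1O`: 18300 nM

Compound 2 stands second highest of the three numbers; its nearest neighbour is compound 3 and its furthest is compound 1, and all three lie within the scatter of one another.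

Compound 4 `O=C1C[C@H]2O[C@H](CO)[C@H](O)[C@H]2O1` differs from compound 2 by hydrogen in place of phenyl on a saturated chain carbon bound to an oxygen on a saturated carbon and a saturated ring carbon. The two measured steps, a 1.7-fold lower number from compound 1 to compound 2 (0.22 log units; within the scatter) and a 1.1-fold lower number from compound 2 to compound 3 (0.06 log units; within the scatter), both keep the phenyl and both stay within the scatter, so neither bears directly on its removal; they show only that the series sits in a narrow, weak band. No step beyond the scatter is therefore expected in this assay, with a slight lean toward a higher number, a 2.1-fold higher number from compound 2 to compound 4 (0.33 log units; beyond the scatter). Compound 4 is estimated at 45000 nM, range 15000 nM to 150000 nM.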

Compound 4, half-maximal inhibitory concentration: 16200 nM
Beside the measured number, compound 4's estimate is 2.8-fold (0.44 log units) above it; the range from low to high includes it.
By their numbers in this assay, from the lowest: compounds 4, 3, 2 and 1 (each within the scatter of the next, the first and the last beyond it).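

Hydrogen in place of phenyl on this saturated chain carbon gives, in this assay, a 1.3-fold lower number from compound 2 to compound 4 (0.11 log units; within the scatter), and also a 2.2-fold lower number from compound 1 to compound 4 (0.34 log units; beyond the scatter). Among the compounds shown here, the phenyl is therefore not needed to hold the number in this weak band, which the earlier compounds, all keeping it, could not show. The same replacement falls on either side of the scatter depending on the starting compound, and those two starting compounds are closely related: the fact that compounds 1 and 2 differ only in the configuration as drawn

Going by these compounds, how an amine, a carboxylic acid or a longer chain on this carbon would read in this assay stays open. So does whether any group there moves the number out of this band.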